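This account rests on a few compounds, and the source may have more. Where it says the series, first, only, none or still open, it means among the compounds named here.

Compound 2, with structure `COc1ccc(C(=O)/C=C/c2cc(-c3cc(OC)c(OC)c(OC)c3)n[nH]2)cc1`, is one of two compounds whose cytotoxicity has been recorded in a functional assay on HCT-116 cells (Homo sapiens) for cytotoxicity, read by sulforhodamine B assay, with a stated time of 48 h, tested at 100 uM; a lower number here means a stronger effect, a higher number a weaker effect of the compound at the concentration tested; there compound 2 gives -10%. For the measured compounds named here, its only neighbour is compound 1, structure `COc1ccc(C(=O)/C=C/c2cc(-c3cc(OC)c(OC)c(OC)c3)n[nH]2)cc1OC`, which in this assay gives -13%. Going by the values given here, the one step between them, a number 3 percentage points higher from compound 1 to compound 2 (within the scatter), leaves the reading where it was. Compound 2 thus stands at the upper of the two numbers, though nothing separates it from compound 1 beyond the scatter.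

Compound 3, structure `COc1cc(-c2cc(/C=C/C(=O)c3ccc(F)c(F)c3)[nH]n2)cc(OC)c1OC`, has not yet been tested. It differs from compound 2 in one place: 3,4-difluorophenyl in place of 4-methoxyphenyl on a carbonyl carbon. Among the compounds with values here, no measured step touches the aryl group on the carbonyl carbon, so nothing in the data points in either direction; the lone step known, from compound 1 to compound 2, was within the scatter. Compound 3 is therefore expected to show no change beyond the scatter, a step of a number 2 percentage points higher from compound 2 to compound 3 (within the scatter) in this assay. The estimate for compound 3 is -8%, with a range from -25% to 15%.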

Compound 3, a percentage reported as activity, at one concentration (the size of the read-out at that concentration, not a potency): -52%
Beside the measured number, compound 3's estimate is 44 percentage points above it, and the stated range ends above it.
By their numbers in this assay, from the lowest: compound 3; then compounds 1 and 2 (each within the scatter of the next).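

In this assay, the aryl group on the carbonyl carbon proves to be a place where the reading can move: 3,4-difluorophenyl in place of 4-methoxyphenyl gives a number 42 percentage points lower from compound 2 to compound 3 (beyond the scatter) and 3,4-difluorophenyl in place of 3,4-dimethoxyphenyl gives a number 39 percentage points lower from compound 1 to compound 3 (beyond the scatter) as well. For the compounds shown here, the only earlier step, a number 3 percentage points higher from compound 1 to compound 2 (within the scatter) on removal of one methoxy from that same aryl group, gave no sign of this, so the two methoxy-bearing compounds read alike while the difluorinated one stands apart. The data at hand offer no explanation for this difference.

From the compounds shown here alone, it remains open whether both fluorines are needed, and what a 4-fluorophenyl, an unsubstituted phenyl or a 4-aminophenyl would give on that carbonyl carbon. Going by these compounds, since each reading comes from a single concentration, the stronger effect of compound 3 is known only at that concentration, and its effect at any other concentration also remains open.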